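The compounds below may be only part of what the source reports. "The series", "measured", "known", "first", "only" and "open" are said of these compounds alone.

Working notes on the series, read in a functional assay on B16 cells (Mus musculus) for antiproliferative activity, with a stated time of 72 h; a lower number here means a stronger inhibitor, a higher number a weaker inhibitor. Compound 1 `OC[C@H]1O[C@@H](n2cnc3c(NCc4ccccc4Br)ncnc32)[C@H](O)[C@@H]1O` gives no number, only a limit: compound 1 stands at > 166000 nM. Compound 2 `COc1cccc(CNc2ncnc3c2ncn3[C@@H]2O[C@H](CO)[C@@H](O)[C@H]2O)c1` likewise gives only a limit, with compound 2 at > 166000 nM. Compound 3 `OC[C@H]1O[C@@H](n2cnc3c(NCc4c(F)ccc(F)c4F)ncnc32)[C@H](O)[C@@H]1O` is also a limit, with compound 3 at > 166000 nM. Among the compounds with values here, no measured compound can therefore be ranked against another.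

The next step leads to compound 4 `OC[C@H]1O[C@@H](n2cnc3c(NCc4ccccc4OC(F)(F)F)ncnc32)[C@H](O)[C@@H]1O`. The change is trifluoromethoxy in place of bromo on an aromatic carbon, ortho to a large group. The closest measured changes are exchanges on the same aromatic ring: a step that the two limits leave unreadable from compound 1 to compound 2, a step that the two limits leave unreadable from compound 1 to compound 3 and a step that the two limits leave unreadable from compound 2 to compound 3. None of these has a readable size, and none shows a compound moving off the limit.

The expectation for compound 4 rests on (the limit of > 166000 nM in this assay, at which 3 of the 3 values shown sit). No step beyond the scatter is expected in this assay, in either direction, and a report as a limit is the likely outcome. The expected change is a step that the limit leaves unreadable from compound 1 to compound 4. For compound 4 the estimate is 170000 nM, with an expected range of 80000 nM to 350000 nM.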

Compound 4, half-maximal inhibitory concentration: > 166000 nM
Compound 4: no number, only a limit; the forecaster's own chance of this, stated with the estimate: 90%; the middle value is on the limit's open side.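

Compound 4 also gives only a limit, > 166000 nM, and compound 1 is likewise a limit, so no new step can be read from the exchange of bromo for trifluoromethoxy. The compounds shown leave open whether any group on this aromatic ring would give a readable value in this assay, or how such groups would rank.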